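This account rests on a few compounds, and the source may have more. Where it says the series, first, only, none or still open, it means among the compounds named here.

Measured compounds:
- compound 1, `O=C(CSc1nc(Nc2ccccc2)c2ccccc2n1)Nc1ccccc1Br`, gives 19800 nM in a functional assay on PC-3 cells (Homo sapiens) for inhibition, read by MTT assay, with a stated time of 72 h; on this read-out higher numbers stand for weaker inhibition and lower numbers for stronger inhibition
- compound 2, `O=C(CSc1nc(Nc2ccccc2)c2ccccc2n1)Nc1cccc(Cl)c1`, gives 12600 nM in this assay
- compound 3, `O=C(CSc1nc(Nc2ccccc2)c2ccccc2n1)Nc1ccc([N+](=O)[O-])cc1`, gives 25000 nM in this assay

All three share the same core and differ only in the aromatic ring attached to the amide nitrogen. Compound 3 sits at one end of the three numbers, but a 1.3-fold higher number from compound 1 to compound 3 (0.10 log units; within the scatter) and a 2.0-fold higher number from compound 2 to compound 3 (0.30 log units; within the scatter) both fall within the scatter, so the three compounds are not separated by these measurements. Compound 4, `O=C(CSc1nc(Nc2ccccc2)c2ccccc2n1)Nc1ccc(C(F)(F)F)cc1`, has not yet been measured. It differs from compound 3 in one place: trifluoromethyl in place of nitro on an aromatic carbon. Among the measured compounds shown here, the steps that bear on this are the ones that also change the substituent on that ring, a 1.3-fold higher number from compound 1 to compound 3 (0.10 log units; within the scatter) and a 2.0-fold higher number from compound 2 to compound 3 (0.30 log units; within the scatter), and both stayed within the scatter. The swap of a nitro for a trifluoromethyl at the same position is therefore expected to give no step beyond the scatter, a 1.3-fold lower number from compound 3 to compound 4 (0.10 log units; within the scatter). Compound 4 is estimated at 20000 nM, with a range from 8000 nM to 50000 nM.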

Compound 4, half-maximal inhibitory concentration: 10400 nM
Compound 4: the middle estimate sits 1.9-fold (0.28 log units) above what was measured, within the range that was stated.
By their numbers in this assay, from the lowest: compounds 4, 2, 1 and 3 (each within the scatter of the next, the first and the last beyond it).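

In this assay, among the compounds shown here, the change of nitro to trifluoromethyl at this place on the ring gives the first step beyond the scatter (a 2.4-fold lower number from compound 3 to compound 4 (0.38 log units; beyond the scatter)), although that step is modest. For the compounds shown here, it shows that the group on this ring can shift the number measurably even when its place stays the same, yet the shift separates only this one pair, as the other two steps (a 1.2-fold lower number from compound 2 to compound 4 (0.08 log units; within the scatter) and a 1.9-fold lower number from compound 1 to compound 4 (0.28 log units; within the scatter)) stay within the scatter. There is no evidence here that explains why the swap has this effect.

On these data alone, what an amine, a carboxylic acid or a longer chain would do at this same place remains open. So does whether trifluoromethyl would give a similar number elsewhere on the ring.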